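Freeing the hydroxy of compound 1

The source may report more compounds than this note shows. Statements on the series, on what has been measured and on what is new or still open speak of the compounds shown alone.

Measured in a functional assay on A549 cells (Homo sapiens) for antiproliferative activity, read by MTT assay, with a stated time of 24 h; a lower number here means a stronger inhibitor, a higher number a weaker inhibitor:
compound 1 `C=CCOc1ccc(-c2ccc(OC)cc2)cc1CC=C`: > 100000 nM
compound 2 `C=CCc1cc(-c2ccccc2C(F)(F)F)ccc1O`: 59700 nM
compound 3 `C=CCc1cc(C=O)c(OCC)c(-c2ccc(OCC)c(CC=C)c2)c1`: 39000 nM

Compound 1 has no numerical value in this assay, only a limit, (the limit of > 100000 nM in this assay, at which 1 of the 3 values shown sits).

Compound 4 `C=CCc1cc(-c2ccc(OC)cc2)ccc1O` has hydrogen in place of allyl on an oxygen on an aromatic ring, allyloxy to hydroxy (hydrogen in place of allyl on an oxygen on an aromatic ring). Going by the values given here, no measured pair shows this change alone, so the expectation is indirect. A shift toward stronger inhibition in this assay is expected, since compound 2, which also carries a hydroxy, gives 59700 nM in that test. The expected size is an at least 2.0-fold lower number from compound 1 to compound 4 (0.30 log units; that floor lies within the scatter), an estimate bounded on one side only. Compound 4 is estimated at 50000 nM, with an expected range from 20000 nM to 100000 nM as its measurement is awaited.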

Compound 4, half-maximal inhibitory concentration: > 100000 nM
Compound 4: a limit, no number; the forecaster's own chance of this, stated with the estimate: 15%; at least 2.0-fold (0.30 log units) between middle value and limit.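

Compound 1 and compound 4 both stand only at a limit in this assay, so no step between them can be read: the limit of > 100000 nM in this assay, at which 2 of the 4 values shown sit.

From the compounds shown here alone, what the change from allyloxy to hydroxy does on the core of compound 1 stays open.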